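The compounds below may be only part of what the source reports. "The series", "measured", "known", "first", "only" and "open" are said of these compounds alone.

Measured in an ADME assay on liver for metabolic stability, with Liver microsome (Homo sapiens) as the target, read by LC-MS, using microsomes; a lower number here means slower removal, a higher number faster removal of the compound:
- compound 1 `O=C(NCc1cc(Cl)ccc1-n1cnnn1)[C@@H]1C[C@@H]2C[C@@H]2N1C(=O)[C@H](O)c1cccc(Cl)c1`: > 500 mL.min-1.g-1 (a limit of the assay)
- compound 2 `CC(C)(C)C[C@@H](O)C(=O)N1N=CC[C@H]1C(=O)NCc1cc(Cl)ccc1-n1cnnn1`: 22 mL.min-1.g-1
- compound 3 `CC(C)(C)[C@@H](O)C(=O)N1CC(=O)C[C@H]1C(=O)NCc1cc(Cl)ccc1-n1cnnn1`: < 12 mL.min-1.g-1 (a limit of the assay)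

Only compound 2 has an exact reading in this assay, at 22 mL.min-1.g-1. Compound 1 reads > 500 mL.min-1.g-1, which is a limit and not a number. Compound 3 reads < 12 mL.min-1.g-1, which is also a limit. Compound 2 therefore sits between two limits, with no exact neighbour on the scale.

Compound 4 `COC(C)(C)[C@@H](O)C(=O)N1N=CC[C@H]1C(=O)NCc1cc(Cl)ccc1-n1cnnn1` differs from compound 2 at one place, with 1-methoxy-1-methylethyl in place of neopentyl on a saturated chain carbon bound to a carbonyl carbon and an oxygen on a saturated carbon. Among the compounds with values here, no measured pair shows this change, so the data offer no step size to carry over. The expected size of the step of a 1.2-fold lower number from compound 2 to compound 4 (0.09 log units; within the scatter) lies within the usual scatter, with no firm direction in this assay. For compound 4 the estimate is 18 mL.min-1.g-1, with an expected range of 12 mL.min-1.g-1 to 40 mL.min-1.g-1.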

Compound 4, intrinsic clearance in microsomes: < 12 mL.min-1.g-1
Compound 4 ended at the assay's limit (the forecaster's own chance of this, stated with the estimate: 20%); middle value at least 1.5-fold (0.17 log units) from the limit.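

Within the data shown here, in the first one-place pair of the series, 1-methoxy-1-methylethyl in place of neopentyl on a saturated chain carbon bound to a carbonyl carbon and an oxygen on a saturated carbon gives an at least 1.8-fold lower number from compound 2 to compound 4 (0.26 log units; that floor lies within the scatter). In this assay compound 4 gives < 12 mL.min-1.g-1, which is a limit of the assay and not a number. The full size of this step remains unknown, and its floor alone does not separate the two compounds, with the new reading resting at the low end of the scale: the limit of < 12 mL.min-1.g-1 in this assay, at which 2 of the 4 values shown sit.

The compounds shown do not separate the contribution of the ether oxygen from that of the changed carbon skeleton. On these data alone, how a primary amine or a carboxylic acid on this chain would read in this assay also remains open.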